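This account rests on a few compounds, and the source may have more. Where it says the series, first, only, none or still open, it means among the compounds named here.

Measured so far:
- compound 1 `Cc1cc(O)c(C2=NN(c3ccc(S(N)(=O)=O)cc3)C(c3ccccc3O)C2)cc1Cl`: 3480 nM
- compound 2 `Cc1cc(O)c(C2=NN(c3ccc(S(N)(=O)=O)cc3)C(/C=C/c3ccccc3)C2)cc1Cl`: 34800 nM

In a functional assay on KM12 cells (Homo sapiens) for antiproliferative activity, with a stated time of 48 h (on this read-out lower numbers stand for stronger inhibition of growth and higher numbers for weaker inhibition of growth), compound 2 gives the highest of the two numbers. Within the data shown here, the one measured step that bears on the saturated ring carbon, a 10-fold higher number from compound 1 to compound 2 (1.00 log units; beyond the scatter), shows that an aryl group there is favoured over the chain-linked ring. Compound 3 `COc1ccc(C2CC(c3cc(Cl)c(C)cc3O)=NN2c2ccc(S(N)(=O)=O)cc2)cc1OC` differs from compound 2 by 3,4-dimethoxyphenyl in place of 2-phenylethenyl on a saturated ring carbon. Returning an aryl group to this position is expected to bring the number back down, though by how much the single step cannot tell. Compound 3 is therefore expected to give about 6000 nM, within 2000 nM to 20000 nM, an expected step of a 5.8-fold lower number from compound 2 to compound 3 (0.76 log units; beyond the scatter).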

Compound 3, concentration for total growth inhibition: 8770 nM
Beside the measured number, compound 3's estimate is 1.5-fold (0.16 log units) below it; low and high end bracket the measured number.
By their numbers in this assay, from the lowest: compound 1; then compound 3; then compound 2.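

In this assay, a 4.0-fold lower number from compound 2 to compound 3 (0.60 log units; beyond the scatter) shows that a second aryl group on the saturated ring carbon also outperforms 2-phenylethenyl, so the earlier preference now holds for both aryl compounds shown. The aryl groups are not interchangeable, since a 2.5-fold higher number from compound 1 to compound 3 (0.40 log units; beyond the scatter) places 3,4-dimethoxyphenyl behind 2-hydroxyphenyl. No measurement here explains either step.

Going by these compounds, how a 2-methoxyphenyl or 4-hydroxyphenyl group would compare at this carbon remains open. So does the effect of an amine, a carboxylic acid or a longer chain there.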